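Dimethoxy Aryl Ketone Extension of a Pyrazolo-Fused Enone Series

The compounds below may be only part of what the source reports. "The series", "measured", "known", "first", "only" and "open" are said of these compounds alone.

Compound 3 `COc1cc(-c2cc(/C=C/C(=O)c3ccccc3)nc3cc(-c4ccccc4)nn23)cc(OC)c1OC` gives 34300 nM in a functional assay on DU-145 cells (Homo sapiens) for antiproliferative activity, read by MTT assay, with a stated time of 24 h (on this read-out lower numbers stand for stronger inhibition and higher numbers for weaker inhibition), the highest of the three numbers recorded here. Compound 2 `COc1cc(-c2cc(/C=C/C(=O)c3ccc(C)cc3)nc3cc(-c4ccccc4)nn23)cc(OC)c1OC` gives 27100 nM in this assay, and compound 1 `COc1ccc(-c2cc(/C=C/C(=O)c3ccc(OC)c(OC)c3)nc3cc(-c4ccccc4)nn23)cc1` gives 16400 nM. Compound 4 `COc1ccc(C(=O)/C=C/c2cc(-c3cc(OC)c(OC)c(OC)c3)n3nc(-c4ccccc4)cc3n2)cc1OC` has not been measured; it differs from compound 3 by 3,4-dimethoxyphenyl in place of phenyl on a carbonyl carbon.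

Going by the values given here, only one single-point step is available, and it touches the same ring: a 1.3-fold higher number from compound 2 to compound 3 (0.10 log units; within the scatter). Among the compounds with values here, it offers no measured precedent for two methoxy groups at that place. The comparison of compound 1 with compound 3 involves two changes at once, so only their two values can be set side by side; they point toward a somewhat lower number where the dimethoxyphenyl ketone is present.

On this basis the step from compound 3 to compound 4 is expected to be a 1.7-fold lower number from compound 3 to compound 4 (0.23 log units; within the scatter), a modest move toward a lower number that may not clear the scatter. Compound 4 is therefore estimated at 20000 nM, within a range from 9000 nM to 45000 nM.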

Compound 4, half-maximal inhibitory concentration: 29900 nM
For compound 4 the middle estimate is 1.5-fold (0.17 log units) below the measured one, within the range that was stated.
By their numbers in this assay, from the lowest: compounds 1, 2, 4 and 3 (each within the scatter of the next, the first and the last beyond it).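

On the carbonyl carbon, 3,4-dimethoxyphenyl in place of phenyl gives a 1.1-fold lower number from compound 3 to compound 4 (0.06 log units; within the scatter) in this assay, and in place of 4-methylphenyl it gives a 1.1-fold higher number from compound 2 to compound 4 (0.04 log units; within the scatter), so the three aryl ketones shown cannot be told apart in this assay. With the 3,4-dimethoxyphenyl ketone held constant, 3,4,5-trimethoxyphenyl in place of 4-methoxyphenyl on an aromatic carbon gives a 1.8-fold higher number from compound 1 to compound 4 (0.26 log units; within the scatter), so neither single change linking compound 1 to compound 3 through compound 4 clears the scatter. Nothing available here accounts for these values.

The compounds shown leave open whether an amine or a carboxylic acid on the ketone aryl ring would move the number beyond the scatter. They also leave open whether replacing the phenyl shared by all four compounds with a pyridine ring would matter.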